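Swapping the para group: from amide to sulfonamide

This account rests on a few compounds, and the source may have more. Where it says the series, first, only, none or still open, it means among the compounds named here.

Three compounds share one core and differ only in the group on the outer ring:
compound 1, `CCc1ccc(Nc2nccc(-c3ccccn3)n2)cc1`, 2100 nM
compound 2, `CN(C)c1ccc(Nc2nccc(-c3ccccn3)n2)cc1`, 3300 nM
compound 3, `CC(=O)N(C)c1ccc(Nc2nccc(-c3ccccn3)n2)cc1`, 1800 nM

These numbers come from a functional assay for inhibition, with Homo sapiens as the target; on this read-out lower numbers stand for stronger inhibition and higher numbers for weaker inhibition. Compound 3 gives the lowest of the three values, yet its steps to the others are small: a 1.2-fold lower number from compound 1 to compound 3 (0.07 log units; within the scatter) and a 1.8-fold lower number from compound 2 to compound 3 (0.26 log units; within the scatter). Likewise a 1.6-fold higher number from compound 1 to compound 2 (0.20 log units; within the scatter) stays within the scatter. So far, then, changing the group at this position has not moved the read-out beyond noise.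

Compound 4, `NS(=O)(=O)c1ccc(Nc2nccc(-c3ccccn3)n2)cc1`, continues this series: sulfamoyl in place of acetyl(methyl)amino on an aromatic carbon. The change swaps one uncharged group for another at the same place. All three measured steps bear on it, since each also exchanges this group, and each stayed within the scatter. No step beyond the scatter is therefore expected in this assay from compound 3 to compound 4, that is a 1.1-fold higher number from compound 3 to compound 4 (0.05 log units; within the scatter). Compound 4 is accordingly estimated at 2000 nM, with a likely range from 800 nM to 5000 nM.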

Compound 4, half-maximal inhibitory concentration: 4600 nM
Beside the measured number, compound 4's estimate is 2.3-fold (0.36 log units) below it, within the range that was stated.
By their numbers in this assay, from the lowest: compounds 3, 1, 2 and 4 (each within the scatter of the next, the first and the last beyond it).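

In this assay, among the compounds shown here, this position no longer looks silent: a 2.6-fold higher number from compound 3 to compound 4 (0.41 log units; beyond the scatter) and a 2.2-fold higher number from compound 1 to compound 4 (0.34 log units; beyond the scatter) are the first steps to pass beyond the scatter, though both are modest. The third new step, a 1.4-fold higher number from compound 2 to compound 4 (0.14 log units; within the scatter) stays within the scatter, so sulfamoyl on this aromatic carbon can be told apart from acetyl(methyl)amino and from ethyl, but not from dimethylamino. Of the groups compared, sulfamoyl alone carries a hydrogen-bond donor, yet that count by itself does not tie the donor to the shift.

From the compounds shown here alone, whether a methyl group on the sulfamoyl nitrogen, or a carboxylic acid or a plain amine at the same place, would give a value like that of sulfamoyl remains open. Nothing measured here explains why these steps arise.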